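Replacing the formyl group of compound 2 with hydrogen

This account rests on a few compounds, and the source may have more. Where it says the series, first, only, none or still open, it means among the compounds named here.

Measured in a functional assay on HUVEC cells (Homo sapiens) for antiproliferative activity, read by MTT assay, with a stated time of 24 h (on this read-out lower numbers stand for stronger inhibition and higher numbers for weaker inhibition), so far
- compound 1 `C=CCc1cc(-c2cccc(C(F)(F)F)c2)ccc1O` gives 76000 nM
- compound 2 `C=CCc1cc(C=O)c(OCC(=O)OCC)c(-c2ccc(OCC(=O)OCC)c(CC=C)c2)c1` gives 86900 nM

On these two numbers, compound 2 lies within the scatter of compound 1. Among the measured compounds shown here, compound 3 `C=CCc1ccc(OCC(=O)OCC)c(-c2ccc(OCC(=O)OCC)c(CC=C)c2)c1` remains unmeasured and has hydrogen in place of formyl on an aromatic carbon of compound 2 hydrogen in place of formyl on an aromatic carbon as its only change. For the measured compounds named here, no step between measured compounds that differ in one place is available, so no shift beyond the scatter is expected in this assay and no direction is favoured. The estimated step is a 1.1-fold lower number from compound 2 to compound 3 (0.04 log units; within the scatter) and stays within the scatter. For compound 3 the expected value is 80000 nM with an estimated range from 35000 nM to 180000 nM as its bounds.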

Compound 3, half-maximal inhibitory concentration: > 100000 nM
Compound 3 ended at the assay's limit (the forecaster's own chance of this, stated with the estimate: 20%); middle value at least 1.2-fold (0.09 log units) from the limit.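

In this assay, among the compounds shown here, hydrogen in place of formyl on this aromatic carbon gives an at least 1.1-fold higher number from compound 2 to compound 3 (0.06 log units; that floor lies within the scatter) as the only step read at this position so far. Compound 3 gives > 100000 nM as a limit of the assay, not a number. The step is only a floor, yet it shows that losing formyl brings no gain within the range this read-out covers: the limit of > 100000 nM in this assay, at which 1 of the 3 values shown sits.

On these data alone, how far compound 3 lies past the limit stays open, so the size of the formyl contribution cannot be read. As far as these compounds go, whether an amine or a carboxylic acid on this carbon would shift the number beyond the scatter also stays open.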